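Chloro to Trifluoromethyl: Expected Cytotoxicity Step

The compounds below may be only part of what the source reports. "The series", "measured", "known", "first", "only" and "open" are said of these compounds alone.

Compound 1 `O=S(=O)(NCCNc1nccc(-c2c(-c3cccc(F)c3)nc3sccn23)n1)c1ccc(F)cc1` gives 9450 nM
Compound 2 `O=S(=O)(NCCNc1nccc(-c2c(-c3cccc(F)c3)nc3sccn23)n1)c1ccc(Cl)cc1` gives 18600 nM

In a functional assay on SK-MEL-28 cells (Homo sapiens) for cytotoxicity, read by MTT assay (on this read-out higher numbers stand for weaker inhibition and lower numbers for stronger inhibition), compound 2 stands alongside compound 1, the only other number shown, and a 2.0-fold higher number from compound 1 to compound 2 (0.29 log units; within the scatter) keeps both within the scatter. Compound 3 `O=S(=O)(NCCNc1nccc(-c2c(-c3cccc(F)c3)nc3sccn23)n1)c1ccc(C(F)(F)F)cc1` differs from compound 2 by trifluoromethyl in place of chloro on an aromatic carbon. Among the measured compounds shown here, the only measured step bearing on this change is a 2.0-fold higher number from compound 1 to compound 2 (0.29 log units; within the scatter), itself within the scatter. The step in this assay from compound 2 to compound 3 is therefore expected to be small, with no direction beyond the scatter, a 1.3-fold higher number from compound 2 to compound 3 (0.11 log units; within the scatter). Compound 3 is estimated at 24000 nM, with a range from 8000 nM to 75000 nM.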

Compound 3, half-maximal inhibitory concentration: 8450 nM
For compound 3 the middle estimate is 2.8-fold (0.45 log units) above the measured one; measured number inside the range.
By their numbers in this assay, from the lowest: compounds 3, 1 and 2 (each within the scatter of the next, the first and the last beyond it).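

Among the compounds shown here, at this place on the aromatic ring, para to a large group, trifluoromethyl in place of chloro gives the first step in this assay that lies beyond the scatter, a 2.2-fold lower number from compound 2 to compound 3 (0.34 log units; beyond the scatter). Trifluoromethyl in place of fluoro gives a 1.1-fold lower number from compound 1 to compound 3 (0.05 log units; within the scatter), so compound 3 and compound 1 cannot be told apart here, and the one step beyond the scatter involves chloro. No available evidence accounts for this step.

All three compounds carry a halogen-containing group at this place. From the compounds shown here alone, what an amine or a carboxylic acid there would give in this assay remains open.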